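Cytotoxicity notes: from compound 2 to compound 3

A few compounds are considered here, and "the series" means these few. Any claim that something is new, unique, unknown or untested is made for them only; others in the source may bear on it.

Within the data shown here, in an ADME assay on MT2 cells (Homo sapiens) for cytotoxicity, read by XTT assay, with a stated time of 4 days (on this read-out lower numbers stand for higher toxicity in this test and higher numbers for lower toxicity in this test), compound 2 (`Cc1cc(/C=C/C(=O)O)cc(C)c1Oc1ccc(N)c(Nc2ccc(C#N)cc2)n1`) gives 15700 nM, the higher of the two numbers so far, while compound 1 (`Cc1cc(C#CC2CC2)cc(C)c1Oc1ccc(N)c(Nc2ccc(C#N)cc2)n1`) gives 5710 nM. Compound 3 (`CC(=O)CCc1cc(C)c(Oc2ccc(N)c(Nc3ccc(C#N)cc3)n2)c(C)c1`) carries 2-acetylethyl in place of 2-carboxyethenyl on an aromatic carbon, and the counted difference is 2-acetylethyl in place of 2-carboxyethenyl on an aromatic carbon. Among the measured compounds shown here, only one measured step bears on this change: a 2.7-fold higher number from compound 1 to compound 2 (0.44 log units; beyond the scatter), with 2-carboxyethenyl entering in place of 2-cyclopropylethynyl. For the measured compounds named here, no measured compound carries 2-acetylethyl, so this single step gives only a weak guide. Losing 2-carboxyethenyl reversed would point towards lower numbers, so a modest step downwards is expected in this assay, of about the size of that measured step. The estimated change is a 2.1-fold lower number from compound 2 to compound 3 (0.32 log units; beyond the scatter). For compound 3 the expected value is 7500 nM, with an estimated range of 3000 nM to 17000 nM.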

Compound 3, half-maximal cytotoxic concentration: 18400 nM
For compound 3 the middle estimate is 2.5-fold (0.39 log units) below the measured one; the measured number lies above the stated range.
By their numbers in this assay, from the lowest: compound 1; then compounds 2 and 3 (each within the scatter of the next).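

In this assay, the step to the new compound reads a 1.2-fold higher number from compound 2 to compound 3 (0.07 log units; within the scatter): at this position, meta to two methyl groups, 2-acetylethyl and 2-carboxyethenyl cannot be told apart, although the exchange removes the hydrogen-bond donor and one double bond outside aromatic rings. The other new step reads a 3.2-fold higher number from compound 1 to compound 3 (0.51 log units; beyond the scatter), so two different groups now stand apart from 2-cyclopropylethynyl, and among the compounds shown the low number belongs to compound 1 alone. Nothing available here accounts for these numbers.

Going by these compounds, it remains open whether the low number of compound 1 goes with the ring of 2-cyclopropylethynyl or with the rest of that group. On these data alone, it is equally open whether an amine or a longer chain at this position would stay level with compound 2 and compound 3 or fall towards compound 1.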